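One more methyl on the chain: compound 2 to compound 3

The source may hold more compounds than are shown below. What is called first, only, known or untested is meant among the compounds shown, and "the series" means these compounds.

- compound 1 `CC(=O)OC[C@@H]1C=C[C@H](n2cc(F)c(N)nc2=O)O1`: > 100000 nM
- compound 2 `CCCC(=O)OC[C@@H]1C=C[C@H](n2cc(F)c(N)nc2=O)O1`: > 100000 nM

In a functional assay on CCRF-CEM cells (Homo sapiens) for antiproliferative activity (a lower number here means a stronger inhibitor, a higher number a weaker inhibitor), compound 1 gives > 100000 nM, which is a limit and not a number. Compound 2 gives > 100000 nM, again only a limit. Compound 2 therefore stands with compound 1 at the limit of > 100000 nM in this assay, at which 2 of the 2 values shown sit.

The next compound is compound 3 `CCCCC(=O)OC[C@@H]1C=C[C@H](n2cc(F)c(N)nc2=O)O1`, and the change is methyl in place of hydrogen on a saturated chain carbon, three bonds along the chain from a carbonyl carbon. Among the compounds with values here, the one measured step that bears on this is a step that the two limits leave unreadable from compound 1 to compound 2. It also extends the chain, but it offers no size to carry forward, so no shift beyond the scatter is expected in this assay. The expected change is a number no higher from compound 2 to compound 3 (the limit leaves the size open). Compound 3 is estimated at 100000 nM, with an expected range from 50000 nM to 200000 nM.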

Compound 3, half-maximal inhibitory concentration: 124000 nM
Beside the measured number, compound 3's estimate is 1.2-fold (0.09 log units) below it; the range from low to high includes it.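

Compound 3 gives a measured number, but compound 1 and compound 2 give only limits, so the steps leading to compound 3 cannot be read as sizes. The compounds shown leave open whether lengthening the chain changes the result at all in this assay.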